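From hydroxy(phenyl)methyl to propylcarbonyl on a shared core

The source may hold more compounds than are shown below. What is called first, only, known or untested is meant among the compounds shown, and "the series" means these compounds.

Of the compounds shown here, three that share a core have been measured in a functional assay on HL-60 cells (Homo sapiens) for inhibition, with a stated time of 48 h (on this read-out higher numbers stand for weaker inhibition and lower numbers for stronger inhibition), so far. Compound 2 (`C#CCOC(=O)C1=C(N)Oc2ccc(-c3cc(OC)cc(OC)c3)cc2C1CC(O)c1ccccc1`) gives 100000 nM and has the highest of the three numbers, so it is the weakest inhibitor among them. Compound 3 (`CCCC(=O)CC1C(C(=O)OCC)=C(N)Oc2ccc(-c3cc(OC)cc(OC)c3)cc21`) gives 27300 nM and compound 1 (`C#CCOC(=O)C1=C(N)Oc2ccc(-c3cc(OC)cc(OC)c3)cc2C1CC(=O)c1ccccc1`) gives 7300 nM on the same read-out.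

Compound 4 (`C#CCOC(=O)C1=C(N)Oc2ccc(-c3cc(OC)cc(OC)c3)cc2C1CC(=O)CCC`) has not been measured. It differs from compound 2 in one place, with propylcarbonyl in place of hydroxy(phenyl)methyl on a saturated chain carbon bound to a saturated ring carbon.

Among the measured compounds shown here, one measured step bears on this change. It is a 14-fold higher number from compound 1 to compound 2 (1.14 log units; beyond the scatter) with hydroxy(phenyl)methyl replacing benzoyl, a large step beyond the scatter. For the measured compounds named here, compound 4 regains a carbonyl, but with a propyl chain where benzoyl has its phenyl ring, and no measured step isolates that swap. Compound 3 also carries propylcarbonyl, though with a different ester, and its value of 27300 nM sits under that of compound 2.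

A clear fall in the number is therefore expected, probably short of the full distance to compound 1. The expected step is a 6.7-fold lower number from compound 2 to compound 4 (0.82 log units; beyond the scatter) in this assay as a move toward stronger inhibition. The estimated value for compound 4 is 15000 nM with an expected range from 5000 nM to 45000 nM around it.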

Compound 4, half-maximal inhibitory concentration: 6900 nM
Compound 4: the middle estimate sits 2.2-fold (0.34 log units) above what was measured; low and high end bracket the measured number.
By their numbers in this assay, from the lowest: compounds 4 and 1 (each within the scatter of the next); then compound 3; then compound 2.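

In this assay, among the compounds shown here, the step of a 1.1-fold lower number from compound 1 to compound 4 (0.02 log units; within the scatter) shows that propyl can stand in place of phenyl on the carbonyl carbon without a change beyond the scatter, a swap that no earlier pair could test. The step of a 14-fold lower number from compound 2 to compound 4 (1.16 log units; beyond the scatter) then places compound 2 apart from both carbonyl-bearing compounds with the same ester, so among these three, a phenyl ring on the side chain does not go with the lower numbers, and only compound 2 carries hydroxy(phenyl)methyl. The step of a 4.0-fold lower number from compound 3 to compound 4 (0.60 log units; beyond the scatter), with ethynyl in place of methyl in the ester, adds that a change away from this side chain also moves the number, though only modestly.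

Nothing measured here explains why any of these steps has the size it does. On these data alone, it remains open whether a longer chain or a cyclohexyl ring on the carbonyl carbon would keep the number this low, and whether a hydroxy group on a propyl-bearing chain would raise it as far as in compound 2.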